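Changing the group on the sulfonyl sulfur of compound 3

The compounds below may be only part of what the source reports. "The series", "measured", "known", "first", "only" and "open" are said of these compounds alone.

- Compound 1 `Cn1c(=O)c(C(=O)Nc2ccc(F)cc2)cc2cnc(Nc3ccc4[nH]ccc4c3)nc21` gives 5000 nM
- Compound 2 `Cn1c(=O)c(S(=O)(=O)Nc2ccc(F)cc2)cc2cnc(Nc3ccc4[nH]ccc4c3)nc21` gives 5000 nM
- Compound 3 `Cn1c(=O)c(S(=O)(=O)Nc2ccc(F)cc2F)cc2cnc(Nc3ccc4[nH]ccc4c3)nc21` gives 5000 nM

All three values come from a functional assay on DU-145 cells (Homo sapiens) for inhibition, read by trypan blue exclusion, with a stated time of 72 h (a lower number here means a stronger inhibitor, a higher number a weaker inhibitor), and compound 3 stands level with compound 1 and compound 2 on these numbers. Compound 4 `Cn1c(=O)c(S(=O)(=O)c2ccc(F)cc2N)cc2cnc(Nc3ccc4[nH]ccc4c3)nc21` keeps the shared core and differs from compound 3 in one place: 2-amino-4-fluorophenyl in place of (2,4-difluorophenyl)amino on a sulfonyl sulfur.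

Within the data shown here, two measured steps bear on this change. Replacing (4-fluorophenyl)carbamoyl with (4-fluorophenyl)sulfamoyl gave no change at the digits printed from compound 1 to compound 2 (within the scatter) and adding a fluoro in place of hydrogen gave no change at the digits printed from compound 2 to compound 3 (within the scatter) in turn. Neither step removes the (2,4-difluorophenyl)amino group, so the data offer no direct guide to this swap. With both earlier steps flat, no shift beyond the scatter in this assay is the most reasonable expectation, and no direction is favoured with any confidence. The expected step is a 1.3-fold lower number from compound 3 to compound 4 (0.10 log units; within the scatter) on this estimate. The range is kept wide, since this change is larger than either measured step. For compound 4 the estimate is 4000 nM and the expected range runs from 600 nM to 10000 nM as a rough guide.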

Compound 4, half-maximal inhibitory concentration: 3000 nM
Compound 4: middle estimate off by 1.3-fold (0.12 log units), on the high side, within the range that was stated.
By their numbers in this assay, from the lowest: compounds 4, 1, 2 and 3 (each within the scatter of the next).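

Among these compounds, replacing the (2,4-difluorophenyl)amino group with 2-amino-4-fluorophenyl on the sulfonyl sulfur changes more than the earlier steps did, yet in this assay it gives a 1.7-fold lower number from compound 3 to compound 4 (0.22 log units; within the scatter) and so stays within the usual scatter. The comparisons with the other two compounds read the same way, with a 1.7-fold lower number from compound 2 to compound 4 (0.22 log units; within the scatter) and a 1.7-fold lower number from compound 1 to compound 4 (0.22 log units; within the scatter) also printed as within the scatter. This extends the flat picture from small edits to a larger swap, since a ring carrying an amino group on the sulfonyl sulfur reads no differently from the earlier groups, and nothing shown here gives a reason for this sameness.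

The compounds shown leave open whether the amino group of compound 4 matters at all, which a plain 4-fluorophenyl on the sulfonyl sulfur or a carboxylic acid in place of that amine could test. They also leave open whether an aromatic ring is needed at this place, a question that a methyl group or a morpholine ring on the sulfonyl sulfur could address.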